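The source may report more compounds than this note shows. Statements on the series, on what has been measured and on what is new or still open speak of the compounds shown alone.

Three compounds have been measured in a physicochemical assay for solubility, with a stated time of 18 h, at pH 7.4; a lower number here means a less soluble compound, a higher number a more soluble compound:

compound 1 `COc1cccc(CNCCCNc2ccnc3cc(-c4cccc5ccccc45)ccc23)c1O` gives 32000 nM;
compound 2 `COc1cccc(CNCCCNc2ccnc3cc(CC(C)C)ccc23)c1O` gives 4200 nM;
compound 3 `COc1ccc(-c2ccc3c(NCCCNCc4cccc(OC)c4O)ccnc3c2)cc1` gives 32000 nM.

Compound 3 stands level with compound 1 at the digits reported, the two together being the highest of the three numbers in this assay; the step of no change at the digits printed from compound 1 to compound 3 (within the scatter) lies within the scatter, whereas compound 2 sits apart, the step of a 7.6-fold higher number from compound 2 to compound 3 (0.88 log units; beyond the scatter) lying beyond it. Compound 4 `COc1cccc(CNCCCNc2ccnc3cc(C4CCCCC4)ccc23)c1O` has not yet been measured. It differs from compound 3 in one place: cyclohexyl in place of 4-methoxyphenyl on an aromatic carbon. Among the compounds with values here, the measured step that bears most directly on this change is the one in which a group lacking an aromatic ring, isobutyl, was replaced by 4-methoxyphenyl: a 7.6-fold higher number from compound 2 to compound 3 (0.88 log units; beyond the scatter). The change from compound 3 to compound 4 runs the other way, putting a group without an aromatic ring where 4-methoxyphenyl stood, so a lower number in this assay is expected, of a size comparable to that step. Cyclohexyl is not isobutyl, though, and the exact size is uncertain. Compound 4 is therefore estimated at 6000 nM, within 2000 nM to 18000 nM. That estimate means a step of a 5.3-fold lower number from compound 3 to compound 4 (0.73 log units; beyond the scatter), expected to lie beyond the scatter.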

Compound 4, solubility: 4200 nM
Beside the measured number, compound 4's estimate is 1.4-fold (0.15 log units) above it; the measured number falls inside the stated range.
By their numbers in this assay, from the lowest: compounds 2 and 4 (each within the scatter of the next); then compounds 1 and 3 (each within the scatter of the next).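

In this assay, within the data shown here, the earlier compounds offered only isobutyl as a group without an aromatic ring at this aromatic carbon, and cyclohexyl now shows that a non-aromatic ring of carbon only reads the same as that open chain, with no change at the digits printed from compound 2 to compound 4 (within the scatter). Set against the aromatic groups, cyclohexyl gives a 7.6-fold lower number from compound 3 to compound 4 (0.88 log units; beyond the scatter) and also a 7.6-fold lower number from compound 1 to compound 4 (0.88 log units; beyond the scatter), so the four compounds fall on two levels: compounds 1 and 3, with an aromatic ring at this position, and compounds 2 and 4, without one, and none of the four goes against this split. The split is a description of the numbers only, and nothing available here accounts for it.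

The compounds shown leave open whether the split follows the aromatic ring as such or holds only for the all-carbon groups and the methoxy-bearing ring seen so far. A pyridin-3-yl ring, a morpholine or a carboxylic acid at this position could show on which level, if either, such groups fall in this assay.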